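A few compounds are considered here, and "the series" means these few. Any claim that something is new, unique, unknown or untested is made for them only; others in the source may bear on it.

Compound 1 `COCCOc1cc2oc(=O)n(CCC(=O)O)c2cc1Cl` stands highest of the three numbers in an assay for inhibition of kynurenine 3-monooxygenase (Homo sapiens), read by mass spectrometry, with a stated time of 1 h (on this read-out lower numbers stand for stronger inhibition and higher numbers for weaker inhibition), giving 31.6 nM. Compound 2 `Cc1ccc([C@@H](C)Oc2cc3onc(CCC(=O)O)c3cc2Cl)nn1` gives 2 nM and compound 3 `C[C@@H](Oc1cc2onc(CCC(=O)O)c2cc1Cl)c1ccccn1` gives 5.01 nM, both on a different core, so their gap to compound 1 cannot be traced to one change. Compound 4 `C[C@@H](Oc1cc2oc(=O)n(CCC(=O)O)c2cc1Cl)c1ncccn1` differs from compound 1 by a group of 8 heavy atoms (6 carbon, 2 nitrogen; one six-membered aromatic ring with 2 hetero atoms) in place of a group of 4 heavy atoms (3 carbon, 1 oxygen; no ring), on an oxygen on an aromatic ring. Going by the values given here, the only single step among the measured compounds, a 2.5-fold higher number from compound 2 to compound 3 (0.40 log units; beyond the scatter), shows that swapping one six-membered aromatic ring with hetero atoms for another moves this assay modestly. With an aromatic ring on the chain carbon, as in compounds 2 and 3, one expects a lower number for compound 4, estimated at a 4.0-fold lower number from compound 1 to compound 4 (0.60 log units; beyond the scatter), giving 8 nM with a range from 3 nM to 25 nM.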

Compound 4, half-maximal inhibitory concentration: 5.01 nM
Compound 4: the middle estimate sits 1.6-fold (0.20 log units) above what was measured; the measured number falls inside the stated range.
By their numbers in this assay, from the lowest: compound 2; then compounds 3 and 4 (each within the scatter of the next); then compound 1.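

On the core of compound 1, the group on the oxygen on an aromatic ring proves a position that moves this assay: the group with one six-membered aromatic ring with 2 hetero atoms in place of 2-methoxyethyl gives a 6.3-fold lower number from compound 1 to compound 4 (0.80 log units; beyond the scatter) in a single change. The earlier compounds shown here offered no step at this position on this core. No evidence is available to account for this step.

Going by these compounds, the step swaps the whole group at once, so the part of it that carries the change remains open. On these data alone, how a phenyl ring or an amine on the same chain carbon would read also remains open.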